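One Hydroxy Group Added to a Urea Acid

The source may report more compounds than this note shows. Statements on the series, on what has been measured and on what is new or still open speak of the compounds shown alone.

compound 1 `Cc1cc(NC(=O)Nc2ccc(C(=O)O)cc2)c2ccccc2n1` — > 25000 nM
compound 2 `Cc1cc(NC(=O)Nc2ccc(N(C)C)cc2)c2ccccc2n1` — > 25000 nM
compound 3 `Cc1cc(NC(=O)Nc2ccc(C(=O)O)c(O)c2)c2ccccc2n1` — not yet measured

Of the compounds shown here, two built on the same urea core have been tested for how much of them is needed to harm liver-derived cells. In an ADME assay on HepG2 cells (Homo sapiens) for cytotoxicity, with a stated time of 72 h (a higher number here means that more compound is needed for the effect, a lower number that less compound is needed), compound 1 gives > 25000 nM, which is a limit of the assay rather than a number. Compound 2 gives > 25000 nM, also a limit. Among the measured compounds shown here, the single step between them, a step that the two limits leave unreadable from compound 1 to compound 2, is therefore unreadable, and the only firm point is the limit of > 25000 nM in this assay, at which 2 of the 2 values shown sit. Compound 3 differs from compound 1 by hydroxy in place of hydrogen on an aromatic carbon. For the measured compounds named here, no measured step bears on this change, and nothing suggests a move away from the limit, so compound 3 is expected to sit at the limit too, with the step that the limit leaves unreadable from compound 1 to compound 3 expected to be nothing beyond the scatter. The estimate for compound 3 in this assay is 30000 nM, between 15000 nM and 100000 nM.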

Compound 3, half-maximal effective concentration: > 25000 nM
Compound 3 ended at the assay's limit; the forecaster's own chance of this, stated with the estimate: 85%; the middle value is on the limit's open side.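

No size can be given for the change from compound 1 to compound 3, as both results are limits of the assay: the limit of > 25000 nM in this assay, at which 3 of the 3 values shown sit. On these data alone, what stays open in this assay is the concentration at which compound 1, compound 2 or compound 3 would harm the cells, and whether the added hydroxy shifts it.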